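Propyl-to-butyl step on the second core: compound 4 expected

The compounds below may be only part of what the source reports. "The series", "measured", "known", "first", "only" and "open" are said of these compounds alone.

Compound 1 `CCCn1c(=O)n(C)c(=O)c2[nH]cnc21` gives 1900 nM in an assay on membranes from brain for displacement of a labelled ligand from adenosine receptor A1 (Cavia porcellus); on this read-out higher numbers stand for weaker inhibition and lower numbers for stronger inhibition. Compound 2 `CCCn1c(=O)n(CC)c(=O)c2[nH]cnc21` gives 1400 nM in this assay, and the change methyl in place of hydrogen on a saturated chain carbon bound to an aromatic nitrogen produced a 1.4-fold lower number from compound 1 to compound 2 (0.13 log units; within the scatter). Compound 3 `CCCn1cnc2c1c(=O)[nH]c(=O)n2CCC` gives 18200 nM in this assay; the difference between the core of compound 3 and the core of compound 1 is not broken down here. Compound 4 `CCCCn1cnc2c1c(=O)[nH]c(=O)n2CCC` differs from compound 3 by methyl in place of hydrogen on a saturated chain carbon, three bonds along the chain from an aromatic nitrogen, the same kind of change as from compound 1 to compound 2, though there the place was bound to an aromatic nitrogen rather than three bonds along the chain from it. Resting on compound 1 and compound 2 with a 1.4-fold lower number from compound 1 to compound 2 (0.13 log units; within the scatter), the step of a 1.4-fold lower number from compound 3 to compound 4 (0.15 log units; within the scatter) is expected, small. Compound 4 is therefore estimated at 13000 nM, between 6000 nM and 30000 nM.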

Compound 4, inhibition constant: 12100 nM
Beside the measured number, compound 4's estimate is 1.1-fold (0.03 log units) above it; measured number inside the range.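

In this assay, methyl in place of hydrogen at the end of the propyl chain gives a 1.5-fold lower number from compound 3 to compound 4 (0.18 log units; within the scatter). Set beside the earlier step on the other core, the change carries over with no difference that can be read: the same change on two cores in this assay, a 1.4-fold lower number (0.13 log units; within the scatter) from compound 1 to compound 2 and a 1.5-fold lower number (0.18 log units; within the scatter) from compound 3 to compound 4, 1.1-fold (0.04 log units) apart, within the scatter of two such steps. Going by these compounds alone, this shows only that the step stays small on both cores, at two different places on the chain; with neither step beyond the scatter, it does not show that the change moves the number at all, and two pairs make no rule for the series.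

Still open, on these data alone, is whether a chain longer than butyl would stay equally silent at this place. As far as these compounds go, a butyl chain ending in an amine or a carboxylic acid is equally open.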